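The source may report more compounds than this note shows. Statements on the series, on what has been measured and on what is new or still open speak of the compounds shown alone.

Measured so far:
compound 1 `Cc1cc(C)nc(-n2nc(C)c3c2NC(=O)CC3c2ccc(COc3cccc(Cl)c3)cc2)n1` gives 3000 nM in a functional assay on HEK293 cells for agonist activity at G-protein coupled receptor 39 (Homo sapiens), read by scintillation proximity assay and inositol phosphate accumulation, with a stated time of 75 min; on this read-out higher numbers stand for an effect only at larger amounts of compound and lower numbers for an effect already at smaller amounts
compound 2 `Cc1nn(-c2ncnc3nc[nH]c23)c2c1C(c1ccc(OC(C)C)cc1)CC(=O)N2` gives 2700 nM in this assay

Compound 2 carries the lower of the two numbers in this assay, but its value and that of compound 1 lie within the scatter of each other, so no order can be read between them. Going by the values given here, no two measured compounds differ in a single place, so no step has been quantified.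

Compound 3 `Cc1nn(-c2ncnc3nc[nH]c23)c2c1C(OCc1ccccc1Cl)CC(=O)N2` differs from compound 2 by (2-chlorobenzyl)oxy in place of 4-isopropoxyphenyl on a saturated ring carbon. The point of attachment stays the saturated ring carbon; what hangs from it changes from an aromatic group to a (2-chlorobenzyl)oxy group. Among the compounds with values here, with no measured step to rest on, the expectation is a weakening somewhat beyond the scatter, given as a 2.2-fold higher number from compound 2 to compound 3 (0.35 log units; beyond the scatter). The estimate for compound 3 in this assay is 6000 nM, with a range from 1500 nM to 25000 nM.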

Compound 3, half-maximal effective concentration: 47 nM
For compound 3 the middle estimate is 130-fold (2.11 log units) above the measured one, and the stated range ends above it.
By their numbers in this assay, from the lowest: compound 3; then compounds 2 and 1 (each within the scatter of the next).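

In this assay, going by these compounds alone, the only quantified step is a large one: replacing 4-isopropoxyphenyl with (2-chlorobenzyl)oxy on the saturated ring carbon gives a 57-fold lower number from compound 2 to compound 3 (1.76 log units; beyond the scatter). This shows that the number is highly sensitive to what hangs from this carbon, and that an aromatic ring attached directly to it is not needed for the lower number, since in compound 3 the group is attached through its oxygen. No measured data bear on the reason for the size of this step.

Because the whole group changes at once, the separate contributions of the oxygen link and the chlorine stay unresolved. Also open, as far as these compounds go, are how a benzyloxy group without chlorine or an amine at this carbon would read, and whether (2-chlorobenzyl)oxy gives a similar step on the core of compound 1.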